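This account rests on a few compounds, and the source may have more. Where it says the series, first, only, none or still open, it means among the compounds named here.

Compound 1 `COc1cccc(/C=C2\CCC/C(=C\c3ccccc3Cl)C2=O)c1OC` gives 10300 nM in a functional assay on SW-620 cells (Homo sapiens) for cytotoxicity, read by MTT assay, with a stated time of 72 h (a lower number here means a stronger inhibitor, a higher number a weaker inhibitor), the lowest of the two numbers measured, though its separation from compound 2 lies within the scatter. Compound 2 `COc1ccc(/C=C2\CCC/C(=C\c3cccc(OC)c3OC)C2=O)cc1` gives 13600 nM in this assay, the step being a 1.3-fold higher number from compound 1 to compound 2 (0.12 log units; within the scatter). Compound 3 `COc1cccc(/C=C2\CCC/C(=C\c3ccc(O)cc3)C2=O)c1OC` differs from compound 1 by 4-hydroxyphenyl in place of 2-chlorophenyl on a double-bonded chain carbon bound to a double-bonded ring carbon. For the measured compounds named here, the only measured step at this place, a 1.3-fold higher number from compound 1 to compound 2 (0.12 log units; within the scatter), lay within the scatter, so no step beyond the scatter is expected in this assay. Compound 3 is therefore estimated at 10000 nM, with a range of 4000 nM to 25000 nM. The expected step is a 1.0-fold lower number from compound 1 to compound 3 (0.01 log units; within the scatter).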

Compound 3, half-maximal inhibitory concentration: > 20000 nM
Compound 3 was reported as a limit (the forecaster's own chance of this, stated with the estimate: 5%); middle value at least 2.0-fold (0.30 log units) away from the limit.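

In this assay compound 3 stands as a limit, not a number: the limit of > 20000 nM in this assay, at which 1 of the 3 values shown sits. Read as a floor, the change to 4-hydroxyphenyl gives an at least 1.9-fold higher number from compound 1 to compound 3 (0.28 log units; that floor lies within the scatter), and hydrogen in place of methyl on the oxygen gives an at least 1.4-fold higher number from compound 2 to compound 3 (0.16 log units; that floor lies within the scatter). For the compounds shown here, neither floor clears the scatter, so this position still shows no firm change, although compound 3 is the first of the series to give a limit rather than a number.

Going by these compounds, how far compound 3 lies past its limit stays open, and so does the true size of both steps. Also open, on these data alone, is whether a phenyl group carrying an amine or a carboxylic acid at this place would move the number beyond the scatter.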